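The source may hold more compounds than are shown below. What is called first, only, known or untested is meant among the compounds shown, and "the series" means these compounds.

Compound 1, `O=C1NCCN1c1ccc(S(=O)(=O)Nc2ccccc2)cc1`, is the reference point of this small set. In a functional assay on HT-29 cells (Homo sapiens) for antiproliferative activity, read by sulforhodamine B assay, with a stated time of 48 h (on this read-out higher numbers stand for weaker inhibition and lower numbers for stronger inhibition), compound 1 gives 280 nM, the lowest number among the three measured compounds. Compound 2, `O=C1NCCN1c1ccc(S(=O)(=O)Nc2ccc(OC(F)F)cc2)cc1`, gives 650 nM in this assay, and compound 3, `CCCCOc1ccc(NS(=O)(=O)c2ccc(N3CCNC3=O)cc2)cc1`, gives 630 nM. Both substituted analogues sit above compound 1: a 2.3-fold higher number from compound 1 to compound 2 (0.37 log units; beyond the scatter) and a 2.3-fold higher number from compound 1 to compound 3 (0.35 log units; beyond the scatter), while between the two substituted compounds a 1.0-fold lower number from compound 2 to compound 3 (0.01 log units; within the scatter).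

Compound 4, `Cc1ccc(NS(=O)(=O)c2ccc(N3CCNC3=O)cc2)c(C)c1`, differs from compound 1 as follows: 2,4-dimethylphenyl in place of phenyl on a sulfonamide nitrogen. The two measured steps that bear on this change are those from compound 1 to compound 2 and from compound 1 to compound 3, each of which adds a single group to the aromatic ring on the sulfonamide nitrogen and each of which raised the number by a modest amount beyond the scatter. For the measured compounds named here, compound 4 instead carries two methyl groups on that ring, so no measured step matches it exactly. On the evidence of compound 2 and compound 3, a modest rise in this assay is expected, a 1.6-fold higher number from compound 1 to compound 4 (0.21 log units; within the scatter), though a result within the scatter of compound 1 cannot be excluded. Compound 4 is therefore estimated to give 450 nM, with a plausible range from 200 nM to 1000 nM.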

Compound 4, half-maximal inhibitory concentration: 180 nM
Beside the measured number, compound 4's estimate is 2.5-fold (0.40 log units) above it; measured number below the stated range.
By their numbers in this assay, from the lowest: compounds 4 and 1 (each within the scatter of the next); then compounds 3 and 2 (each within the scatter of the next).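

In this assay the 2,4-dimethylphenyl group on a sulfonamide nitrogen cannot be told apart from phenyl, since a 1.6-fold lower number from compound 1 to compound 4 (0.19 log units; within the scatter) is the step printed for this change. The earlier compounds shown here showed only rises when a group was added to the ring on that nitrogen, with a 2.3-fold higher number from compound 1 to compound 2 (0.37 log units; beyond the scatter) and a 2.3-fold higher number from compound 1 to compound 3 (0.35 log units; beyond the scatter) as the two steps beyond the scatter. Compound 4 goes against that picture and shows that a substituted ring at this place does not by itself raise the number, as the core of compound 1 keeps its standing here with the larger carbon-only group; no measurement offered here accounts for the contrast among compounds 2, 3 and 4.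

The compounds shown leave open what each methyl group contributes alone, since a ring with a single methyl group would be needed to separate the two. They also leave open how this ring would respond to an amine, a carboxylic acid or a chlorine atom, and whether a group larger than 2,4-dimethylphenyl would still stay within the scatter of phenyl.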